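Replacing an amino group with a methyl group

The source may report more compounds than this note shows. Statements on the series, on what has been measured and on what is new or still open speak of the compounds shown alone.

Compound 1 `O=C(O)c1ccc(CN2CCC[C@H](O[C@H](CO)c3cc(Cl)cc(Cl)c3)[C@@H]2c2ccccc2)c([N+](=O)[O-])c1`: 172000 nM
Compound 2 `Nc1cc(C(=O)O)ccc1CN1CCC[C@H](O[C@H](CO)c2cc(Cl)cc(Cl)c2)[C@@H]1c1ccccc1`: 126000 nM

Both numbers come from a physicochemical assay for solubility, at pH 2; on this read-out lower numbers stand for lower solubility and higher numbers for higher solubility. Going by the values given here, compound 2 has only one neighbour on this scale, compound 1, and the two values lie within the usual scatter of repeated measurements, so neither can be ranked above the other.

The next compound is compound 3 `Cc1cc(C(=O)O)ccc1CN1CCC[C@H](O[C@H](CO)c2cc(Cl)cc(Cl)c2)[C@@H]1c1ccccc1`. It keeps the core of compound 2 and changes one group: methyl in place of amino on an aromatic carbon. In words, a methyl group replaces the amino group of compound 2, at the carbon that is ortho to a large group and meta to a carboxy group.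

Among the compounds with values here, only one measured step touches this same carbon. That step, with amino in place of nitro, is a 1.4-fold lower number from compound 1 to compound 2 (0.14 log units; within the scatter). Within the data shown here, no measurement yet shows what methyl does here, so this single small step is a thin guide. On that evidence, no change beyond the scatter is expected in this assay, and no direction can be called. The estimated step is a 1.1-fold lower number from compound 2 to compound 3 (0.06 log units; within the scatter). For compound 3 the expected value is 110000 nM, with an estimated range from 50000 nM to 210000 nM.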

Compound 3, solubility: 196000 nM
The estimate for compound 3 lay 1.8-fold (0.25 log units) below the measured number, and the stated range covers the measured number.
By their numbers in this assay, from the lowest: compounds 2, 1 and 3 (each within the scatter of the next).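

In this assay, putting methyl in place of amino on this aromatic carbon gives a 1.6-fold higher number from compound 2 to compound 3 (0.19 log units; within the scatter), and methyl in place of nitro gives a 1.1-fold higher number from compound 1 to compound 3 (0.06 log units; within the scatter). Going by these compounds alone, this is the first view of a group here that carries no hydrogen-bond donor or acceptor, whereas amino carries one of each, and the exchange still leaves the number within the scatter, so nitro, amino and methyl cannot be ranked at this carbon, ortho to a large group and meta to a carboxy group. Nothing in the data shown offers an explanation for how closely these three compounds agree.

On these data alone, whether any group on this carbon can move the number beyond the scatter remains open, and a methoxy group, a chlorine atom, a primary amide or a longer chain such as propyl would each put that question to the test. It is also open whether the same three-way agreement would hold on a different core, since all three compounds shown share a single core and differ only at this one carbon.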